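Acetamido for methylsulfonyl: clearance expectation for compound 3

The source may report more compounds than this note shows. Statements on the series, on what has been measured and on what is new or still open speak of the compounds shown alone.

In an ADME assay (liver) for pharmacokinetics, with Liver microsome (Rattus norvegicus) as the target, using microsomes (on this read-out lower numbers stand for slow clearance and higher numbers for fast clearance), compound 1 `CNc1nc(NCc2ccc(OC(F)(F)F)cc2)cc(-c2ccccn2)n1` gives > 52.3 mL/min/kg as a limit of the assay and not a number. Within the data shown here, compound 2 `CNc1nc(NCc2ccc(S(C)(=O)=O)cc2)cc(-c2ccccn2)n1` gives 34.1 mL/min/kg in this assay and holds the only actual number so far. Among the measured compounds shown here, the sole measured step (an at least 1.5-fold lower number from compound 1 to compound 2 (0.18 log units; that floor lies within the scatter)) has its floor within the scatter and replaces a different group, so it sets no size for the next change. Compound 3 `CNc1nc(NCc2ccc(NC(C)=O)cc2)cc(-c2ccccn2)n1` carries acetamido in place of methylsulfonyl on an aromatic carbon. The estimated step (a 1.1-fold higher number from compound 2 to compound 3 (0.05 log units; within the scatter)) is expected to stay within the scatter, with no direction favoured. For compound 3 the expected value is 38 mL/min/kg with an estimated range from 20 mL/min/kg to 65 mL/min/kg on this read-out.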

Compound 3, clearance: 35.9 mL/min/kg
Estimate against measurement, compound 3: 1.1-fold (0.02 log units) above; the range from low to high includes it.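

In this assay, acetamido and methylsulfonyl on this aromatic carbon now both give actual numbers, and the two cannot be told apart: a 1.1-fold higher number from compound 2 to compound 3 (0.02 log units; within the scatter). Against trifluoromethoxy, only a floor can be read, and it lies within the scatter: an at least 1.4-fold lower number from compound 1 to compound 3 (0.16 log units; that floor lies within the scatter). Compound 1 stands as a limit of the assay and not a number: the limit of > 52.3 mL/min/kg in this assay, at which 1 of the 3 values shown sits.

On these data alone, whether an amine, a carboxylic acid or a longer chain at this position would give a number set apart from these two stays open. Any change elsewhere on the shared core also stays open.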